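The source may hold more compounds than are shown below. What is called first, only, known or untested is meant among the compounds shown, and "the series" means these compounds.

Measured compounds:
compound 1, `O=C(Nc1cccc(-n2cc(-c3ccncc3)c(-c3ccc(Cl)c(O)c3)n2)c1)Nc1ccc(Cl)c(Cl)c1`, > 32500 nM;
compound 2, `COc1cc(-c2nn(-c3cccc(NC(=O)c4ccc(Cl)c(C(F)(F)F)c4)c3)cc2-c2ccncc2)ccc1Cl`, > 32500 nM;
compound 3, `O=C(Nc1cccc(-n2cc(-c3ccncc3)c(-c3ccc(Cl)c(O)c3)n2)c1)Nc1cc(C(F)(F)F)cc(C(F)(F)F)c1`, 6060 nM.

The study followed three close analogues in a functional assay on M14 cells (Homo sapiens) for inhibition, read by sulforhodamine B assay, with a stated time of 48 h; on this read-out higher numbers stand for lower toxicity in this test and lower numbers for higher toxicity in this test. Compound 1 gave only a limit of the assay, > 32500 nM, and no number. Compound 2 likewise gave only a limit, > 32500 nM. Compound 3 alone gave a number, 6060 nM. Where compound 2 stands is therefore set by a limit, and it shares this position with compound 1, as the limit of > 32500 nM in this assay, at which 2 of the 3 values shown sit, records; compound 3 is the one compound whose toxicity in this assay was resolved.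

The next compound, compound 4, `COc1cc(-c2nn(-c3cccc(NC(=O)Nc4cccc(C(F)(F)F)c4)c3)cc2-c2ccncc2)ccc1Cl`, has not yet been measured. It differs from compound 2 in one place: (3-(trifluoromethyl)phenyl)amino in place of 4-chloro-3-(trifluoromethyl)phenyl on a carbonyl carbon. Through this change, compound 4 becomes a urea like compound 1 and compound 3, and it carries a single trifluoromethyl group on the outer ring.

Going by the values given here, no step between measured compounds is available to guide the size of the change in this assay. Since compound 1 and compound 2 both sit at the limit and compound 3 lies somewhat below it, the expected step from compound 2 to compound 4 is an at least 1.6-fold lower number from compound 2 to compound 4 (0.21 log units; that floor lies within the scatter), a shift toward the measurable range. Compound 4 is expected to give about 20000 nM in this assay, estimated between 6000 nM and 50000 nM.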

Compound 4, concentration lethal to 50% of the cells: 4650 nM
The estimate for compound 4 lay 4.3-fold (0.63 log units) above the measured number; the measured number lies below the stated range.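

Going by these compounds alone, at this position, on a carbonyl carbon whose other neighbour is an amide-type nitrogen, replacing 4-chloro-3-(trifluoromethyl)phenyl with (3-(trifluoromethyl)phenyl)amino gives the first step in one place that can be read in this assay, and it is an at least 6.9-fold lower number from compound 2 to compound 4 (0.84 log units; beyond the scatter). The printed size is a floor and not a full measure of the change, because compound 2 has only a limit: the limit of > 32500 nM in this assay, at which 2 of the 4 values shown sit. The step still lies beyond the scatter, so this place on the molecule can move the read-out out of the limit and into the measurable range, in a swap where the chlorine leaves, an amino nitrogen enters and the entering group carries a hydrogen-bond donor that the leaving group lacks.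

The compounds shown leave open whether the step follows the loss of the chlorine or the entry of the amino nitrogen, as the two arrive together in this single change. They also leave open the true size of the step and how this assay would read with an oxygen atom or a methylene group in place of that nitrogen.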